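A Step from Compound 3 to Compound 4 in Cytotoxicity

The compounds below may be only part of what the source reports. "The series", "measured", "known", "first", "only" and "open" are said of these compounds alone.

The account begins with compound 3, `O=C1/C(=C/c2ccc([N+](=O)[O-])cc2)SC(=S)N1NS(=O)(=O)c1ccccc1`. In a functional assay on ECV-304 cells (Homo sapiens) for cytotoxicity (a higher number here means a weaker inhibitor, a lower number a stronger inhibitor), compound 3 gives > 50000 nM, which is a limit of the assay and not a number. Compound 1, `COc1ccc(S(=O)(=O)NN2C(=S)S/C(=C\c3ccc(Cl)c(Cl)c3)C2O)cc1`, also reaches a limit in this assay, reported as > 50000 nM. Compound 2, `O=C1/C(=C/c2ccc(Cl)c(Cl)c2)SC(=S)N1NS(=O)(=O)c1cccs1`, in this assay likewise gives > 50000 nM, again a limit. So compound 3 stands where every measured value stands, at the limit of > 50000 nM in this assay, at which 3 of the 3 values shown sit, and none of the three compounds can be ordered against another.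

The compound still to be measured is compound 4, `Cc1ccc(/C=C2\SC(=S)N(NS(=O)(=O)c3ccccc3)C2=O)cc1C`. It differs from compound 3 in one place: 3,4-dimethylphenyl in place of 4-nitrophenyl on a double-bonded chain carbon bound to a double-bonded ring carbon. For the measured compounds named here, no step between two measured compounds is available, so nothing in the data shows how a change of this kind moves the read-out, and the three limits give no scale for it.

With every measured compound sitting at the limit, the step that the limit leaves unreadable from compound 3 to compound 4 is expected to be none beyond the scatter, and compound 4 is expected to remain at or near that same limit. Compound 4 is therefore estimated to give 60000 nM in this assay, within a range from 20000 nM to 200000 nM.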

Compound 4, half-maximal inhibitory concentration: > 50000 nM
Compound 4 gave a limit, no number (the forecaster's own chance of this, stated with the estimate: 80%); the middle value lies beyond the limit too.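

Compound 3 and compound 4 both stand at a limit in this assay, so no step can be read between them. All the compounds shown share one position: the limit of > 50000 nM in this assay, at which 4 of the 4 values shown sit. They leave open whether 3,4-dimethylphenyl and 4-nitrophenyl differ at all in this assay, and whether any compound shown has a half-maximal inhibitory concentration that can be given as a number.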